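The source may hold more compounds than are shown below. What is called first, only, known or untested is meant among the compounds shown, and "the series" means these compounds.

Three related compounds have numbers in a functional assay on DU-145 cells (Homo sapiens) for inhibition, read by trypan blue exclusion, with a stated time of 96 h; on this read-out higher numbers stand for weaker inhibition of growth and lower numbers for stronger inhibition of growth. Compound 1 (`Cc1ccc(S/C(=C/c2c[nH]c3ccccc23)C(=O)c2ccc(Br)cc2)cc1`) gives 10000 nM, compound 2 (`COc1ccccc1/C=C(/Sc1ccc(C)cc1)C(=O)c1ccc(Br)cc1`) gives 9000 nM and compound 3 (`COc1ccccc1/C=C(/Sc1ccc(C)cc1)C(=O)c1ccc(Cl)cc1`) gives 25000 nM. Compound 2 and compound 1 therefore sit level at the low end of this short series, within the scatter of each other, while compound 3 stands clearly higher.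

The next compound, compound 4 (`Cc1ccc(S/C(=C/c2c(O)cc(O)cc2O)C(=O)c2ccc(Br)cc2)cc1`), keeps everything in compound 2 except one group: 2,4,6-trihydroxyphenyl in place of 2-methoxyphenyl on a double-bonded chain carbon bound to a double-bonded chain carbon. The change lies on a double-bonded chain carbon bound to a double-bonded chain carbon.

Within the data shown here, only one measured step touches that same place. It is a 1.1-fold lower number from compound 1 to compound 2 (0.05 log units; within the scatter), where 2-methoxyphenyl replaces 1H-indol-3-yl, and it stays within the scatter. The other measured step, a 2.8-fold higher number from compound 2 to compound 3 (0.44 log units; beyond the scatter), is modest and real, but it comes from chloro in place of bromo, so it says little about the group changing here.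

Among the measured compounds shown here, a single swap is thin evidence, and no measured compound carries a 2,4,6-trihydroxyphenyl group. Going by that one swap, no shift beyond the scatter is expected in either direction, though with wide uncertainty. The expected step is a 1.1-fold higher number from compound 2 to compound 4 (0.05 log units; within the scatter). For compound 4 the estimated value is 10000 nM, with an expected range from 3000 nM to 35000 nM.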

Compound 4, concentration for 50% growth inhibition: > 100000 nM
Compound 4 ended at the assay's limit; the forecaster's own chance of this, stated with the estimate: 10%; at least 10-fold (1.00 log units) between middle value and limit.
By their numbers in this assay, from the lowest: compounds 2 and 1 (each within the scatter of the next); then compound 3. At a limit, above all of these: compound 4.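

In this assay compound 4 gives > 100000 nM, which is a limit of the assay and not a number: the limit of > 100000 nM in this assay, at which 1 of the 4 values shown sits.

The earlier swap at this place, a 1.1-fold lower number from compound 1 to compound 2 (0.05 log units; within the scatter), suggested that the group on a double-bonded chain carbon bound to a double-bonded chain carbon could change without consequence, but the new compound shows that this holds only for some groups. Putting 2,4,6-trihydroxyphenyl there gives an at least 11-fold higher number from compound 2 to compound 4 (1.04 log units; beyond the scatter), and the comparison with the other level compound gives an at least 10-fold higher number from compound 1 to compound 4 (1.00 log units; beyond the scatter), so growth inhibition is clearly lost with this group, whichever of the two it replaces.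

The change alters several things at once, going from 0 to 3 hydrogen-bond donors and from 1 to 3 hydrogen-bond acceptors while the methoxy group leaves, so the compounds shown cannot say which of these differences matters. Among these compounds, open, then, is how a plain phenyl, a 2-hydroxyphenyl with its single hydroxy group, or a 2,4,6-trimethoxyphenyl with the same oxygen count but no hydroxy hydrogens would behave at this place.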